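The compounds below may be only part of what the source reports. "The series", "measured", "known", "first", "only" and "open" are said of these compounds alone.

Among the compounds with values here, compound 1 `COC(OC)C1=C(C(=O)OC/C=C/c2ccccc2)C(c2cccc(Cl)c2)C(C(=O)O)=C(C)N1` is the weakest inhibitor among the three measured members: in an assay on thoracic aorta for inhibition of Voltage-gated L-type calcium channel (Rattus norvegicus) (a lower number here means a stronger inhibitor, a higher number a weaker inhibitor), compound 1 gives 8100 nM, the highest number of the three. Its nearest neighbour is compound 3 `COC(OC)C1=C(C(=O)OC/C=C/c2ccc(C(F)(F)F)cc2)C(c2cccc(Cl)c2)C(C(=O)O)=C(C)N1`, for which this assay returns 3200 nM; the furthest is compound 2 `CCC1=C(C(=O)OC/C=C/c2ccccc2)C(c2cccc(Cl)c2)C(C(=O)O)=C(C)N1`, for which this assay returns 7 nM. The two measured steps out of compound 1 are very different in size: a 1200-fold lower number from compound 1 to compound 2 (3.06 log units; beyond the scatter), whereas a 2.5-fold lower number from compound 1 to compound 3 (0.40 log units; beyond the scatter).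

Compound 4 `COc1cccc(/C=C/COC(=O)C2=C(C(OC)OC)NC(C)=C(C(=O)O)C2c2cccc(Cl)c2)c1` has not been measured. It differs from compound 1 by methoxy in place of hydrogen on an aromatic carbon, the group sitting on a six-membered aromatic ring of carbon only, meta to a large group. The change therefore falls on the same aromatic ring that is altered from compound 1 to compound 3, and that modest step is the one that bears on it; the step to compound 2 concerns a double-bonded ring carbon of the shared core and gives no guidance here. On that basis a small step towards a lower number, possibly none beyond the scatter, is expected rather than a large one. For compound 4 the expected step is a 1.6-fold lower number from compound 1 to compound 4 (0.21 log units; within the scatter), which gives an estimated 5000 nM in this assay, with a range from 2000 nM to 15000 nM.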

Compound 4, half-maximal inhibitory concentration: 4400 nM
Beside the measured number, compound 4's estimate is 1.1-fold (0.06 log units) above it, within the range that was stated.
By their numbers in this assay, from the lowest: compound 2; then compounds 3, 4 and 1 (each within the scatter of the next, the first and the last beyond it).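

In this assay, methoxy on an aromatic carbon, meta to a large group, gives a 1.8-fold lower number from compound 1 to compound 4 (0.27 log units; within the scatter), so 3-methoxyphenyl in place of phenyl does not separate compound 4 from compound 1. The ring groups are not separated from each other either: 3-methoxyphenyl in place of 4-(trifluoromethyl)phenyl gives a 1.4-fold higher number from compound 3 to compound 4 (0.14 log units; within the scatter), so compound 4 lies within the scatter of both neighbours, although compound 1 and compound 3 lie just beyond it from each other. Both steps on this aromatic ring remain small beside a 1200-fold lower number from compound 1 to compound 2 (3.06 log units; beyond the scatter), so among these compounds the ring of the 3-phenylprop-2-en-1-yl chain accounts for far less of the spread than ethyl in place of dimethoxymethyl, and nothing at hand gives a reason for either size.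

Still open, from the compounds shown here alone, is whether a different kind of group on this ring, such as an amine or a carboxylic acid, or 4-methoxyphenyl and 3-(trifluoromethyl)phenyl with the two groups exchanged in place, would move the number beyond the scatter. Also open, going by these compounds, is whether ethyl in place of dimethoxymethyl would carry the same large step on the 3-methoxyphenyl or 4-(trifluoromethyl)phenyl compounds.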